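Phenyl for Cyanobenzyl: Solubility Outlook for Compound 4

The source may hold more compounds than are shown below. What is called first, only, known or untested is meant among the compounds shown, and "the series" means these compounds.

Compound 3 `COc1cccc(CNCCCNc2ccnc3cc(Cc4ccc(C#N)cc4)ccc23)c1O` gives 4200 nM in a physicochemical assay for solubility, with a stated time of 18 h, at pH 7.4 (a lower number here means a less soluble compound, a higher number a more soluble compound), the lowest of the three numbers. Compound 1 `COc1ccc(-c2ccc3c(NCCCNCc4cccc(OC)c4O)ccnc3c2)cc1` gives 32000 nM in this assay, and compound 2 `COc1cccc(CNCCCNc2ccnc3cc(-c4ccc(C(C)(C)C)cc4)ccc23)c1O` gives 32000 nM. Compound 4 `COc1cccc(CNCCCNc2ccnc3cc(-c4ccccc4)ccc23)c1O` differs from compound 3 by phenyl in place of 4-cyanobenzyl on an aromatic carbon. For the measured compounds named here, the steps that bear on this change run the other way: a 7.6-fold lower number from compound 1 to compound 3 (0.88 log units; beyond the scatter) and a 7.6-fold lower number from compound 2 to compound 3 (0.88 log units; beyond the scatter), while no change at the digits printed from compound 1 to compound 2 (within the scatter), so the substituent on a directly attached aryl mattered little. Compound 4 again carries a directly attached aryl, and the reverse step is therefore expected to recover most of that loss, a 6.0-fold higher number from compound 3 to compound 4 (0.77 log units; beyond the scatter). For compound 4 the estimate is 25000 nM, with a range from 8000 nM to 60000 nM.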

Compound 4, solubility: 32000 nM
For compound 4 the middle estimate is 1.3-fold (0.11 log units) below the measured one; low and high end bracket the measured number.
By their numbers in this assay, from the lowest: compound 3; then compounds 1, 2 and 4 (each within the scatter of the next).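

In this assay the change from 4-cyanobenzyl to phenyl gives a 7.6-fold higher number from compound 3 to compound 4 (0.88 log units; beyond the scatter) and so separates compound 3 from every other compound shown. The unsubstituted phenyl stands level with both substituted aryl compounds, with no change at the digits printed from compound 2 to compound 4 (within the scatter) and no change at the digits printed from compound 1 to compound 4 (within the scatter), so hydrogen, tert-butyl and methoxy on that ring cannot be told apart here. No measurement shown explains this result.

On these data alone, whether the step belongs to the benzyl link or to the nitrile remains open. So does whether an amine or a carboxylic acid on the phenyl would leave the number unchanged.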